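The source may hold more compounds than are shown below. What is called first, only, known or untested is meant among the compounds shown, and "the series" means these compounds.

Measured compounds:
- compound 1 `CCn1ccc2cc(C(OC(C)=O)c3cc(OC)c(OC)c(OC)c3)ccc21`: in a functional assay on A549 cells (Homo sapiens) for cytotoxicity, read by XTT assay, with a stated time of 72 h (a lower number here means a stronger inhibitor, a higher number a weaker inhibitor), compound 1 gives > 10000 nM, a limit of the assay.
- compound 2 `CCn1ccc2cc(/C(=N\OC(C)=O)c3cc(OC)c(OC)c(OC)c3)ccc21`: in this assay compound 2 gives > 10000 nM, likewise a limit.
- compound 3 `COc1cc(/C(=N/NC(C)=O)c2ccc3c(ccn3C)c2)cc(OC)c1OC`: in this assay compound 3 gives > 10000 nM, again a limit and not a number.

All three measured values sit at the limit of > 10000 nM in this assay, at which 3 of the 3 values shown sit, so compound 3 stands where every other measured compound stands: no number has been obtained for any of them, only a limit.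

Compound 4 `CN/N=C(/c1cc(OC)c(OC)c(OC)c1)c1ccc2c(ccn2C)c1` is not yet measured. It differs from compound 3 in one place: methyl in place of acetyl on an amine nitrogen whose other neighbour is the double-bonded nitrogen. For the measured compounds named here, no measured pair shows the effect of such a change, so no step size can be read from the data. With compound 3 at > 10000 nM, the expectation is that compound 4 most likely also returns a limit in this assay, and any step a number no higher from compound 3 to compound 4 (the limit leaves the size open) is expected to stay within the scatter. The estimate for compound 4 is 10000 nM, with a range from 1500 nM to 60000 nM.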

Compound 4, half-maximal inhibitory concentration: > 1000 nM
Compound 4: a limit, no number; the forecaster's own chance of this, stated with the estimate: 65%; the middle value lies beyond the limit too.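

Compound 3 and compound 4 both return only limits in this assay, so no step can be read between them for methyl in place of acetyl on an amine nitrogen. The compounds shown leave open what number any of them would give, and whether this change shifts activity at all.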